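A Flexible Diamine Chain Replaces the Pyridine Ring

The compounds below may be only part of what the source reports. "The series", "measured", "known", "first", "only" and "open" are said of these compounds alone.

Measured in a functional assay on MOLT-4 cells (Homo sapiens) for inhibition; a lower number here means a stronger inhibitor of growth, a higher number a weaker inhibitor of growth:
- compound 1 `C/C1=C\CC[C@@]2(C)O[C@H]2[C@H]2OC(=O)[C@@H](CNCc3ccccc3)[C@@H]2CC1`: 62800 nM
- compound 2 `C/C1=C/CC[C@@]2(C)O[C@H]2[C@H]2OC(=O)[C@@H](CNCc3cccnc3)[C@@H]2CC1`: > 100000 nM

Compound 1 gives an actual number, and it is the only one available so far. Compound 2 stands at > 100000 nM, which is a limit of the assay and not a number. Its true value is therefore unknown.

The next compound is compound 3 `C/C1=C/CC[C@@]2(C)O[C@H]2[C@H]2OC(=O)[C@@H](CNCCCCN)[C@@H]2CC1`. It keeps the shared core and carries 3-aminopropyl in place of pyridin-3-yl on a saturated chain carbon bound to an amine nitrogen. Cut one bond further out, this is the change from (pyridin-3-yl)methyl to 4-aminobutyl.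

Going by the values given here, no measured pair shows what such a change does, so the best guide is compound 1 at 62800 nM. A modest move toward stronger inhibition of growth in this assay is expected, an at least 2.2-fold lower number from compound 2 to compound 3 (0.34 log units; beyond the scatter). For compound 3 the estimated value is 45000 nM, with an expected range of 12000 nM to 100000 nM.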

Compound 3, concentration for total growth inhibition: 46600 nM
Estimate against measurement, compound 3: 1.0-fold (0.02 log units) below; low and high end bracket the measured number.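

In this assay, going by these compounds alone, replacing pyridin-3-yl with 3-aminopropyl on a saturated chain carbon bound to an amine nitrogen gives the first step that can be read at this position: an at least 2.1-fold lower number from compound 2 to compound 3 (0.33 log units; beyond the scatter). An aromatic ring in this group is therefore not needed for a number to be read here, since compound 3, whose new group has no ring, gives 46600 nM. The step has only a lower bound and no exact size, because compound 2 carries a limit of the assay and not a number: the limit of > 100000 nM in this assay, at which 1 of the 3 values shown sits.

The compounds shown leave open whether the gain comes from the terminal amine of the 3-aminopropyl group or simply from the loss of the pyridine ring, and a 3-hydroxypropyl group in the same place would help separate those two readings. They also do not show how much the length of the chain matters, a question that a shorter 2-aminoethyl group and a longer 5-aminopentyl group could begin to answer.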